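A Nitro Group Added to a Shared Core

A few compounds are considered here, and "the series" means these few. Any claim that something is new, unique, unknown or untested is made for them only; others in the source may bear on it.

Compound 1 `CCOC(=O)C12C(=O)OCC=C1COC2c1ccccc1` was tested in a functional assay on A549 cells (Homo sapiens) for cytotoxicity, read by MTT assay; a higher number here means a weaker inhibitor, a lower number a stronger inhibitor. In this assay compound 1 gives > 1000000 nM, which is a limit of the assay rather than a measured number. Compound 2 `CCOC(=O)C12C(=O)OCC=C1COC2c1ccc(OC)c(OC)c1` gives > 1000000 nM in this assay, also a limit. Compound 3 `CCOC(=O)C12C(=O)OCC=C1COC2c1cc(OC)cc(OC)c1` gives > 1000000 nM in this assay, again a limit. Compound 1 therefore stands where every measured compound stands: the limit of > 1000000 nM in this assay, at which 3 of the 3 values shown sit. Among the compounds with values here, no two measured compounds differ in only one place, so no single measured step is available to guide an expectation.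

Compound 4 `CCOC(=O)C12C(=O)OCC=C1COC2c1ccc([N+](=O)[O-])cc1` has not yet been measured. Compared with compound 1 it carries nitro in place of hydrogen on an aromatic carbon. Within the data shown here, since all three measured compounds sit at the same limit and no measured step exists, the change is expected to produce no step beyond the usual scatter, and the expected step is a number no higher from compound 1 to compound 4 (the limit leaves the size open). Compound 4 is accordingly expected to give about 1000000 nM, within a range from 300000 nM to 3000000 nM, and most likely to be reported only as a limit once more.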

Compound 4, half-maximal inhibitory concentration: 36800 nM
Compound 4: the middle estimate sits 27-fold (1.43 log units) above what was measured, outside the stated range (below it).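

In this assay, nitro in place of hydrogen on an aromatic carbon, para to a large group, gives an at least 27-fold lower number from compound 1 to compound 4 (1.43 log units; beyond the scatter). This shows that the aromatic ring of the shared core is a place where a single change can bring a measurable effect on these cells, something that a set of limits alone could not reveal. Compound 4 is the only compound shown with a measured number, while the others remain at the limit of the assay: the limit of > 1000000 nM in this assay, at which 3 of the 4 values shown sit.

The compounds shown leave open whether this effect belongs to the nitro group specifically, or would also appear with another group at the same place, such as an amine, a nitrile or a carboxylic acid. They also leave open how much the position on the ring matters, since the nitro group is seen at only one place.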